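A few compounds are considered here, and "the series" means these few. Any claim that something is new, unique, unknown or untested is made for them only; others in the source may bear on it.

Measured so far in a functional assay on SH-SY5Y cells (Homo sapiens) for cytotoxicity, read by MTT assay, with stated times of 1 h and 24 h; a lower number here means that less compound is needed, a higher number that more compound is needed for the effect:
- Compound 1 `CN(C)CCC(=O)c1cc2ccc(O)cc2oc1=O`: > 100000 nM (a limit, not a number)
- Compound 2 `CCN(CC)CCC(=O)c1cc2ccc(O)cc2oc1=O`: 13000 nM

Within the data shown here, compound 2 holds the only true number so far, 13000 nM. Compound 1 reports only a limit, > 100000 nM.

The next compound is compound 3 `O=C(CCN1CCCC1)c1cc2ccc(O)cc2oc1=O`. The change from compound 2 is pyrrolidin-1-yl in place of diethylamino on a saturated chain carbon, two bonds along the chain from a carbonyl carbon. In short, pyrrolidin-1-yl stands in place of diethylamino, on a saturated chain carbon, two bonds along the chain from a carbonyl carbon. The group count stays equal, and the new group brings a ring.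

Among the measured compounds shown here, one measured step bears on this, at the same place on the chain: an at least 7.6-fold lower number from compound 1 to compound 2 (0.88 log units; beyond the scatter). It shows that this assay can respond to a change of the amino group here. On these data alone, its full size stays open, as one end of it is a limit: the limit of > 100000 nM in this assay, at which 1 of the 2 values shown sits. That step swapped in a larger group, whereas this one keeps the heavy-atom count, so a smaller step seems likely, perhaps slightly towards a higher number. The expected change is a 1.5-fold higher number from compound 2 to compound 3 (0.19 log units; within the scatter), with no clear move beyond the scatter. For compound 3 the estimated value is 20000 nM, with an expected range of 6000 nM to 70000 nM.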

Compound 3, half-maximal effective concentration: > 100000 nM
Compound 3 was reported as a limit; the forecaster's own chance of this, stated with the estimate: 15%; middle value at least 5.0-fold (0.69 log units) away from the limit.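

In this assay, the step of an at least 7.6-fold higher number from compound 2 to compound 3 (0.88 log units; beyond the scatter) shows that the amino group at this place can matter even when the heavy-atom count stays the same. Diethylamino and pyrrolidin-1-yl have the same count of carbon and nitrogen atoms, and the clear difference between them is that pyrrolidin-1-yl ties those carbons into a ring, so a change in shape alone, with no added atoms, goes with a step beyond the scatter. Compound 2 is now the only one of the three with a true number, the step from compound 1 to compound 3 cannot be read, and the full size of the new step stays unknown, since its upper end is a limit: the limit of > 100000 nM in this assay, at which 2 of the 3 values shown sit.

The compounds shown leave open whether other ring amines at this place, such as piperidin-1-yl or morpholin-4-yl, would behave like pyrrolidin-1-yl, or whether open-chain amines such as dipropylamino would follow diethylamino. They also leave open whether a longer chain between the carbonyl carbon and the amine would change the picture for diethylamino or pyrrolidin-1-yl.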